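Compound 3 without its methoxy: expected effect

The source may hold more compounds than are shown below. What is called first, only, known or untested is meant among the compounds shown, and "the series" means these compounds.

In a functional assay on U-373MG ATCC cells (Homo sapiens) for cytotoxicity, read by MTT assay, with a stated time of 72 h (a higher number here means a weaker inhibitor, a lower number a stronger inhibitor), compound 3 (`COc1ccc2[nH]c3c4cn[nH]c4c4c(c3c2c1)C(=O)NC4=O`) gives 51000 nM and sits within the scatter of the two other measured compounds. For the measured compounds named here, compound 1 (`COc1ccc2[nH]c(-c3ccc[nH]3)cc2c1`) gives 43000 nM in the same test, and compound 2 (`Cc1ccc2[nH]c(-n3cccn3)c(C3=C(Br)C(=O)NC3=O)c2c1`) gives 27000 nM there, so no measured compound separates from the others.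

The next structure is compound 4 (`O=C1NC(=O)c2c1c1[nH]ncc1c1[nH]c3ccccc3c21`), with hydrogen in place of methoxy on an aromatic carbon; hydrogen in place of methoxy on an aromatic carbon is the full count of the change. Going by the values given here, no measured pair isolates a single change, so this replacement has no direct precedent.

In this assay no step beyond the scatter is expected, in either direction. The main support is compound 2, which carries no methoxy, gives 27000 nM and stays within the scatter of the two methoxy compounds. The estimate means a 1.3-fold lower number from compound 3 to compound 4 (0.11 log units; within the scatter) as an expected step, within the scatter. Compound 4 is estimated at 40000 nM with an expected range from 15000 nM to 100000 nM in this test.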

Compound 4, half-maximal inhibitory concentration: > 100000 nM
Compound 4 gave a limit, no number (the forecaster's own chance of this, stated with the estimate: 10%); middle value at least 2.5-fold (0.39 log units) from the limit.
By their numbers in this assay, from the lowest: compounds 2, 1 and 3 (each within the scatter of the next). At a limit, above all of these: compound 4.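

In this assay, for the compounds shown here, replacing methoxy with hydrogen on this aromatic carbon gives the first pair that differs in one place, with an at least 1.9-fold higher number from compound 3 to compound 4 (0.29 log units; that floor lies within the scatter). Compound 4 gives a limit and not a number: the limit of > 100000 nM in this assay, at which 1 of the 4 values shown sits. The change therefore brings no lower number at this position, but because the floor of the step lies within the scatter, the pair does not establish a loss beyond the scatter either.

The true size of the step cannot be read from this pair, so how much the methoxy contributes in this test remains unsettled. Also open, going by these compounds, is whether a hydroxyl, an ethoxy or a fluorine on the same aromatic carbon would read like compound 3 or compound 4.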